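The source may hold more compounds than are shown below. What is called first, only, known or untested is meant among the compounds shown, and "the series" means these compounds.

Measured in a functional assay on MCF7 cells (Homo sapiens) for cytotoxicity, read by MTT assay, with a stated time of 24 h; on this read-out lower numbers stand for stronger inhibition and higher numbers for weaker inhibition:
Compound 1 `COc1cc(/C=C(\C#N)C(=O)N/N=C(\C)c2c(O)c3ccc(O)cc3oc2=O)ccc1O`: 13700 nM
Compound 2 `COc1ccc(/C=C(\C#N)C(=O)N/N=C(\C)c2c(O)c3ccc(O)cc3oc2=O)cc1OC`: 14400 nM
Compound 3 `C/C(=N\NC(=O)/C(C#N)=C/c1ccccc1[N+](=O)[O-])c1c(O)c2ccc(O)cc2oc1=O`: 9180 nM

Compound 3, at 9180 nM, does not stand apart from the other two compounds in this assay, since all three values lie within the scatter of one another. Compound 4 `C/C(=N\NC(=O)/C(C#N)=C/c1ccccc1Cl)c1c(O)c2ccc(O)cc2oc1=O` has yet to be measured. It carries chloro in place of nitro on an aromatic carbon, ortho to a large group (chloro in place of nitro on an aromatic carbon). For the measured compounds named here, no measured step makes this exact exchange, and no measured compound carries a chloro group. The closest evidence comes from the two steps that introduce the 2-nitrophenyl group of compound 3 in place of another substituted phenyl: a 1.5-fold lower number from compound 1 to compound 3 (0.17 log units; within the scatter) and a 1.6-fold lower number from compound 2 to compound 3 (0.20 log units; within the scatter). Both stayed within the scatter, as did the smaller change in a 1.1-fold higher number from compound 1 to compound 2 (0.02 log units; within the scatter). On this limited evidence, no step beyond the scatter is expected in this assay, and no direction can be favoured. The expected step is a 1.1-fold higher number from compound 3 to compound 4 (0.04 log units; within the scatter). For compound 4 the estimated value is 10000 nM, with an expected range from 5000 nM to 20000 nM.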

Compound 4, half-maximal inhibitory concentration: 8880 nM
Beside the measured number, compound 4's estimate is 1.1-fold (0.05 log units) above it; low and high end bracket the measured number.
By their numbers in this assay, from the lowest: compounds 4, 3, 1 and 2 (each within the scatter of the next).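

In this assay, for the compounds shown here, the exchange of nitro for chloro on an aromatic carbon, ortho to a large group, gives a 1.0-fold lower number from compound 3 to compound 4 (0.01 log units; within the scatter) and is the first direct reading of a change at this position: a group of 3 heavy atoms with 2 hydrogen-bond acceptors gives way to a single chlorine atom with none, and the number stays within the scatter. The 2-chlorophenyl group likewise stays within the scatter of the two other substituted phenyl groups, with a 1.6-fold lower number from compound 2 to compound 4 (0.21 log units; within the scatter) for the 3,4-dimethoxyphenyl partner and a 1.5-fold lower number from compound 1 to compound 4 (0.19 log units; within the scatter) for the 4-hydroxy-3-methoxyphenyl partner, so every step among these four compounds lies within the scatter and none goes against that. No measurement is available that could account for this outcome.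

The compounds shown leave open whether an amine or a carboxylic acid on this aromatic carbon would give a step beyond the scatter. They also leave open whether a longer chain in place of chloro would do so, since no group shown here has yet moved the number that far.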